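Swapping Methyl for Chloro on a Shared Core

The source may hold more compounds than are shown below. What is called first, only, known or untested is meant among the compounds shown, and "the series" means these compounds.

Three compounds built on one core have been examined in a functional assay on the whole organism (strain Swiss albino) with Mus musculus as the target, with a stated time of 4 h; a higher number here means that more compound is needed for the effect, a lower number that less compound is needed. Compound 1 `COc1cc2c(cc1OC)C(=O)C(CC1CCN(C(=S)Nc3ccccc3)CC1)C2` gives 300 mg/kg. Compound 2 `COc1cc2c(cc1OC)C(=O)C(CC1CCN(C(=S)Nc3ccc(C)cc3)CC1)C2` gives 300 mg/kg, and compound 3 `COc1cc2c(cc1OC)C(=O)C(CC1CCN(C(=S)Nc3ccccc3Cl)CC1)C2` gives 300 mg/kg. Compound 2 thus stands level with both of its neighbours: the step of no change at the digits printed from compound 1 to compound 2 (within the scatter) and the step of no change at the digits printed from compound 2 to compound 3 (within the scatter) lie within the scatter, as does the step of no change at the digits printed from compound 1 to compound 3 (within the scatter).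

Compound 4 `COc1cc2c(cc1OC)C(=O)C(CC1CCN(C(=S)Nc3ccc(Cl)cc3)CC1)C2` has not yet been measured. It differs from compound 2 by chloro in place of methyl on an aromatic carbon, on an aromatic carbon of a six-membered aromatic ring of carbon only, para to a large group. The measured steps that bear on this all touch the same ring: methyl in place of hydrogen (no change at the digits printed from compound 1 to compound 2 (within the scatter)), chloro in place of hydrogen (no change at the digits printed from compound 1 to compound 3 (within the scatter)), and 2-chlorophenyl in place of 4-methylphenyl (no change at the digits printed from compound 2 to compound 3 (within the scatter)). None of them moved the read-out beyond the scatter. On that basis compound 4 is expected to show no step beyond the scatter, no change at the digits printed from compound 2 to compound 4 (within the scatter). Compound 4 is therefore estimated at 300 mg/kg, within 150 mg/kg to 600 mg/kg.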

Compound 4, minimum effective dose: 300 mg/kg
Estimate against measurement, compound 4: no gap at the digits printed; low and high end bracket the measured number.
By their numbers in this assay, from the lowest: compounds 1, 2, 3 and 4 (each within the scatter of the next).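

In this assay, chloro on an aromatic carbon para to a large group reads the same as methyl there (no change at the digits printed from compound 2 to compound 4 (within the scatter)) and the same as hydrogen (no change at the digits printed from compound 1 to compound 4 (within the scatter)). The 4-chlorophenyl group also matches the 2-chlorophenyl group on the amide-type nitrogen (no change at the digits printed from compound 3 to compound 4 (within the scatter)), so the two chloro placements shown cannot be told apart in this read-out. No evidence accompanies these compounds that would account for the identical readings.

The compounds shown leave open whether any group on this ring can move the read-out, since a methoxy group, a nitro group, an amine or a carboxylic acid is not among them. On these data alone, it also remains open whether a longer chain such as butyl in this place would read differently.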